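Writhing test: carboxymethyl analogue of the pyrazolopyranone methyl series

A few compounds are considered here, and "the series" means these few. Any claim that something is new, unique, unknown or untested is made for them only; others in the source may bear on it.

Going by the values given here, compound 2 `Cc1cc(=O)oc2c1c(C)nn2C` gives 11.6 mg/kg in a functional assay on the whole organism with Mus musculus as the target, in the writhing test (on this read-out lower numbers stand for an effect already at smaller amounts and higher numbers for an effect only at larger amounts of compound), the only number obtained so far. Compound 1 `CCOC(=O)Cc1nn(C)c2oc(=O)cc(C)c12` gives > 100 mg/kg in this assay in this assay, which is a limit of the assay and not a number. The step of an at least 8.6-fold lower number from compound 1 to compound 2 (0.93 log units; beyond the scatter) therefore sits against the limit described as the limit of > 100 mg/kg in this assay, at which 1 of the 2 values shown sits. Compound 3 `Cc1cc(=O)oc2c1c(CC(=O)O)nn2C` has not been measured; it differs from compound 2 by carboxy in place of hydrogen on a saturated chain carbon bound to an aromatic carbon. Among the compounds with values here, the only measured step that bears on this change is an at least 8.6-fold lower number from compound 1 to compound 2 (0.93 log units; beyond the scatter), where a group on the same chain carbon went along with the weaker read-out; the change to compound 3 places a related group at the same position, so a step in the opposite direction, toward a higher number, is expected, with a fair chance that only a limit is reported. For compound 3 the expected step is a 5.2-fold higher number from compound 2 to compound 3 (0.71 log units; beyond the scatter). The estimate for compound 3 is 60 mg/kg, with a range from 20 mg/kg to 150 mg/kg.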

Compound 3, dose for half-maximal effect: > 100 mg/kg
Compound 3: only a limit was reported; the forecaster's own chance of this, stated with the estimate: 45%; at least 1.6-fold (0.22 log units) between middle value and limit.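

In this assay, carboxy in place of hydrogen on the saturated chain carbon bound to an aromatic carbon gives an at least 8.6-fold higher number from compound 2 to compound 3 (0.93 log units; beyond the scatter), so the loss at this place is not confined to the ethyl ester of compound 1. Of the compounds shown, only compound 2, with methyl at this place, gives a number, 11.6 mg/kg. Compound 1 and compound 3 each stand at a limit of the assay and not at a number, so the step between them cannot be read and neither can be placed ahead of the other: the limit of > 100 mg/kg in this assay, at which 2 of the 3 values shown sit.

Still open, on these data alone, is how far past the limit either compound lies. Also open, as far as these compounds go, is whether an amide, an alcohol, an amine or a longer chain in place of carboxy on this chain carbon would give a number in this assay.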